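Hydroxy on the isobutylamino chain: outlook for compound 4

The source may report more compounds than this note shows. Statements on the series, on what has been measured and on what is new or still open speak of the compounds shown alone.

The shared core is the same across the series, differing only in the group on one aromatic carbon. Compound 1 `Cc1cc(Oc2ccc(NC(=O)Nc3cccc(C(F)(F)F)c3)cc2)ncn1` gives 160 nM in an assay on isolated protein for inhibition of serine/threonine-protein kinase TNNI3K (Homo sapiens); a lower number here means a stronger inhibitor, a higher number a weaker inhibitor. Compound 2 `C[C@@H](O)CNc1cc(Oc2ccc(NC(=O)Nc3cccc(C(F)(F)F)c3)cc2)ncn1` gives 63 nM, and compound 3 `CC(C)CNc1cc(Oc2ccc(NC(=O)Nc3cccc(C(F)(F)F)c3)cc2)ncn1` gives 50 nM. Compound 3 stands at the lowest number of the three: the step of a 3.2-fold lower number from compound 1 to compound 3 (0.51 log units; beyond the scatter) is beyond the scatter, whereas the step of a 1.3-fold lower number from compound 2 to compound 3 (0.10 log units; within the scatter) leaves no order between the two amino-bearing chains. Both such chains improved on the methyl of compound 1, with a 2.5-fold lower number from compound 1 to compound 2 (0.40 log units; beyond the scatter) and a 3.2-fold lower number from compound 1 to compound 3 (0.51 log units; beyond the scatter).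

Compound 4 `CC(C)(O)CNc1cc(Oc2ccc(NC(=O)Nc3cccc(C(F)(F)F)c3)cc2)ncn1` is not yet measured. It differs from compound 3 by hydroxy in place of hydrogen on a saturated chain carbon bound to three saturated chain carbons. For the measured compounds named here, the one measured step that bears on a hydroxy within this chain is a 1.3-fold lower number from compound 2 to compound 3 (0.10 log units; within the scatter), within the scatter; taken with a 2.5-fold lower number from compound 1 to compound 2 (0.40 log units; beyond the scatter), it shows that a hydroxy-carrying chain already performs about as well as the isobutyl chain. No step beyond the scatter is therefore expected in this assay for compound 4, in either direction. The expected step is a 1.2-fold higher number from compound 3 to compound 4 (0.08 log units; within the scatter). Compound 4 is estimated at 60 nM, with a range from 30 nM to 130 nM.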

Compound 4, half-maximal inhibitory concentration: 40 nM
For compound 4 the middle estimate is 1.5-fold (0.18 log units) above the measured one, within the range that was stated.
By their numbers in this assay, from the lowest: compounds 4, 3 and 2 (each within the scatter of the next); then compound 1.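

Placing a hydroxy on the saturated chain carbon bound to three saturated chain carbons gives no readable change in this assay: the step of a 1.3-fold lower number from compound 3 to compound 4 (0.10 log units; within the scatter) leaves compound 3 and compound 4 without an order, so the isobutylamino chain takes this hydroxy with no measurable cost or gain. The same holds for the two hydroxy-carrying chains, since a 1.6-fold lower number from compound 2 to compound 4 (0.20 log units; within the scatter) shows that (2-hydroxy-2-methylpropyl)amino and (2-hydroxypropyl)amino cannot be ranked, while a 4.0-fold lower number from compound 1 to compound 4 (0.60 log units; beyond the scatter) shows that the advantage over the methyl of compound 1 persists with this new chain, so all three amino-bearing chains now stand clear of the methyl and level with one another. No measured evidence available here accounts for this flat response at the chain terminus.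

Still open, on these data alone, is whether this carbon accepts a group of a different kind, such as a primary amine, a carboxylic acid or a methoxy in place of the hydroxy, or whether a longer chain on the nitrogen moves the number beyond the scatter. The opposite enantiomer of the (2-hydroxypropyl)amino chain of compound 2 also remains an open comparison.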